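The compounds below may be only part of what the source reports. "The series", "measured", "known", "first", "only" and "open" are said of these compounds alone.

Compound 1 `Fc1cc(Cl)ccc1N1CCN(Cc2ccn3c(CC4CC4)nnc3c2C(F)(F)F)CC1` was tested in a functional assay on HEK293 cells for agonist activity at metabotropic glutamate receptor 8 (Homo sapiens), read by a luciferase reporter and cAMP accumulation; on this read-out higher numbers stand for an effect only at larger amounts of compound and lower numbers for an effect already at smaller amounts. In this assay compound 1 gives > 10000 nM, which is a limit of the assay rather than a number. Compound 2 `Fc1ccc(C2CCN(Cc3ccn4c(CC5CC5)nnc4c3C(F)(F)F)CC2)c(F)c1` shares the same core. In this assay compound 2 gives > 10000 nM, again only a limit. Both values sit at the limit of > 10000 nM in this assay, at which 2 of the 2 values shown sit. Compound 3 `Fc1ccccc1N1CCN(Cc2ccn3c(CC4CC4)nnc3c2C(F)(F)F)CC1` is not yet measured; it differs from compound 1 by hydrogen in place of chloro on an aromatic carbon. Because compound 1 gives > 10000 nM in this assay, a limit, no step beyond the scatter is expected from this change. The step is therefore estimated as a step that the limit leaves unreadable from compound 1 to compound 3. For compound 3 the expected value is 15000 nM, between 5000 nM and 50000 nM.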

Compound 3, half-maximal effective concentration: > 10000 nM
Compound 3 gave a limit, no number; the forecaster's own chance of this, stated with the estimate: 85%; the middle value is on the limit's open side.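

Compound 1 and compound 3 each give only a limit in this assay, so no step between them can be read: the limit of > 10000 nM in this assay, at which 3 of the 3 values shown sit.

What stays open is whether the chloro matters at all, and what amount of any of these compounds would give an effect.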